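The source may report more compounds than this note shows. Statements on the series, on what has been measured and on what is new or still open speak of the compounds shown alone.

Compound 1, `CCCCc1cnc(Cc2ccc(-c3ccccc3C(=O)O)cc2)[nH]1`, gives > 10000 nM in an in vitro functional assay on cells for agonist activity at Bombesin receptor subtype-3 (Mus musculus), read by luminescence and calcium flux; a lower number here means that less compound is needed, a higher number that more compound is needed for the effect. Compound 2, `O=C(O)c1ccccc1-c1ccc(CCc2ncc(C3CCCCC3)[nH]2)cc1`, gives 14.7 nM.

The value for compound 1 is a limit of this assay rather than a number (the limit of > 10000 nM in this assay, at which 1 of the 2 values shown sits). Going by the values given here, compound 2 therefore stands on the only actual number here, with the other entry being a limit. Compound 3, `COc1ccc(Cc2cnc(CCc3ccc(-c4ccccc4C(=O)O)cc3)[nH]2)cc1`, keeps the shared core of compound 2 and differs in one place: 4-methoxybenzyl in place of cyclohexyl on an aromatic carbon. Among the compounds with values here, with no measured step of this kind to lean on, the expected change in this assay is a modest loss, probably somewhat beyond the scatter. Compound 3 is estimated at 50 nM, within 10 nM to 500 nM, an expected step of a 3.4-fold higher number from compound 2 to compound 3 (0.53 log units; beyond the scatter).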

Compound 3, half-maximal effective concentration: 513 nM
Compound 3: middle estimate off by 10-fold (1.01 log units), on the low side, outside the stated range (above it).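

Going by these compounds alone, replacing cyclohexyl with 4-methoxybenzyl in this assay gives a 35-fold higher number from compound 2 to compound 3 (1.54 log units; beyond the scatter), the first measured step at this position on the shared core. It shows that the result here depends strongly on the group this aromatic carbon carries, and that cyclohexyl is clearly the better of the two groups compared. Nothing measured among these compounds gives a reason for this step.

From the compounds shown here alone, whether the loss goes with the aromatic ring or with the methoxy oxygen stays open. So does how a plain benzyl group or a short chain ending in an amine would read at this position.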